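This account rests on a few compounds, and the source may have more. Where it says the series, first, only, none or still open, it means among the compounds named here.

Measured in a functional assay on MCF7 cells (Homo sapiens) for cytotoxicity, read by MTT assay, with a stated time of 72 h; on this read-out lower numbers stand for stronger inhibition and higher numbers for weaker inhibition:
- Compound 1 `COc1cccc(C=C2C(=O)N(c3ccc(Cl)cc3)N(c3ccc(Cl)cc3)C2=O)c1O`: 26700 nM
- Compound 2 `COc1ccc(C=C2C(=O)N(c3ccc(Cl)cc3)N(c3ccc(Cl)cc3)C2=O)cc1`: > 128000 nM
- Compound 3 `COc1ccccc1C=C1C(=O)N(c2ccc(Cl)cc2)N(c2ccc(Cl)cc2)C1=O`: 26300 nM

Compound 2 gives > 128000 nM, which is a limit of the assay, not a number.

Going by the values given here, compound 3 stands level with the only other firm value (a 1.0-fold lower number from compound 1 to compound 3 (0.01 log units; within the scatter)). Compound 4 `O=C1C(=C/C=C/c2ccccc2)C(=O)N(c2ccc(Cl)cc2)N1c1ccc(Cl)cc1` changes one group of compound 3: 2-phenylethenyl in place of 2-methoxyphenyl on a double-bonded chain carbon bound to a double-bonded ring carbon. That is, 2-phenylethenyl takes the place of 2-methoxyphenyl.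

Among the compounds with values here, no measured step makes this exact change. Swaps at this place can matter, as an at least 4.7-fold higher number from compound 1 to compound 2 (0.68 log units; beyond the scatter) and an at least 4.8-fold lower number from compound 2 to compound 3 (0.68 log units; beyond the scatter) show, yet a 1.0-fold lower number from compound 1 to compound 3 (0.01 log units; within the scatter) shows one that does not. No step beyond the scatter is therefore expected in this assay, although either direction remains possible.

The estimated step is a 1.1-fold higher number from compound 3 to compound 4 (0.06 log units; within the scatter).

For compound 4 the expected value is 30000 nM, with an estimated range of 8000 nM to 110000 nM.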

Compound 4, half-maximal inhibitory concentration: 9400 nM
Beside the measured number, compound 4's estimate is 3.2-fold (0.50 log units) above it; the range from low to high includes it.
By their numbers in this assay, from the lowest: compound 4; then compounds 3 and 1 (each within the scatter of the next). At a limit, above all of these: compound 2.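

Going by these compounds alone, until now, the only firm values at this position stood level, with methoxy-bearing phenyl groups on the double-bonded chain carbon. The oxygen-free 2-phenylethenyl group, which adds a double bond outside the aromatic ring, gives the lowest number of the four (a 2.8-fold lower number from compound 3 to compound 4 (0.45 log units; beyond the scatter); a 2.8-fold lower number from compound 1 to compound 4 (0.45 log units; beyond the scatter)). The step from compound 2 is larger (an at least 13-fold lower number from compound 2 to compound 4 (1.13 log units; beyond the scatter)), but compound 2 stands at a limit of the assay: the limit of > 128000 nM in this assay, at which 1 of the 4 values shown sits.

As far as these compounds go, whether a longer chain of conjugated double bonds would lower the number further stays open. So does the effect of an amine or a carboxylic acid on the phenyl ring of the 2-phenylethenyl group.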